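The source may report more compounds than this note shows. Statements on the series, on what has been measured and on what is new or still open speak of the compounds shown alone.

Values in an ADME assay on L02 cells (Homo sapiens) for inhibition, read by CCK-8 assay, with a stated time of 48 h; a higher number here means a weaker inhibitor of growth, a lower number a stronger inhibitor of growth:
- compound 1 `Cc1ccccc1Nc1nc(Nc2ccc(N3CCN(C)CC3)cn2)ncc1Cl`: 5980 nM
- compound 2 `CC(C)c1ccc(Nc2nc(Nc3ccc(N4CCN(C)CC4)cn3)ncc2Cl)cc1`: 13700 nM
- compound 3 `CC(C)c1cccc(Nc2nc(Nc3ccc(N4CCN(C)CC4)cn3)ncc2Cl)c1`: not yet measured

Compound 2, at 13700 nM, has the higher of the two numbers in this assay. Compound 3 has 3-isopropylphenyl in place of 4-isopropylphenyl on a nitrogen on an aromatic ring. Among the measured compounds shown here, no measured compound carries the 3-isopropylphenyl group. For the measured compounds named here, the only measured step that bears on this change is a 2.3-fold higher number from compound 1 to compound 2 (0.36 log units; beyond the scatter), which is modest and replaces a different group. With so little to go on, only a small shift towards compound 1 is expected, and it may not exceed the scatter. The expected step is a 1.4-fold lower number from compound 2 to compound 3 (0.14 log units; within the scatter). Compound 3 is estimated at 10000 nM, with an expected range of 5000 nM to 20000 nM.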

Compound 3, concentration for 50% growth inhibition: 12500 nM
Compound 3: middle estimate off by 1.3-fold (0.10 log units), on the low side; measured number inside the range.
By their numbers in this assay, from the lowest: compound 1; then compounds 3 and 2 (each within the scatter of the next).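

In this assay, there is a 1.1-fold lower number from compound 2 to compound 3 (0.04 log units; within the scatter), so exchanging 4-isopropylphenyl for 3-isopropylphenyl on this nitrogen produces no resolved change in the number. The new compound also gives a 2.1-fold higher number from compound 1 to compound 3 (0.32 log units; beyond the scatter), which places compound 3 on the same side of compound 1 as compound 2, although that step changes both the substituent and its place on the phenyl ring. No measurement offers an explanation for either step.

The compounds shown do not separate the effect of methyl versus isopropyl from that of substituent position, and 2-isopropylphenyl or 4-methylphenyl would each change only one of these relative to a compound here. From the compounds shown here alone, how a carboxylic acid or an amine on this phenyl ring would read in this assay also remains open.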